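A few compounds are considered here, and "the series" means these few. Any claim that something is new, unique, unknown or untested is made for them only; others in the source may bear on it.

Measured compounds:
compound 1, `C=CCNC(=O)[C@@H](NC(=O)[C@@](O)(CCCN(Cc1ccc(Br)cc1)NC(=O)[C@@H](NC(=O)OC)C(C)(C)C)Cc1ccc(CC=C)cc1)C(C)(C)C`: > 50000 nM
compound 2, `COC(=O)N[C@H](C(=O)NN(CCC[C@@]1(O)Cc2ccc(cc2)C/C=C\CNC(=O)[C@H](C(C)(C)C)NC1=O)Cc1ccc(Br)cc1)C(C)(C)C`: 30000 nM

Both compounds were tested in an ADME assay on MT4 cells (Homo sapiens) for cytotoxicity, read by XTT assay, with a stated time of 5 days; on this read-out higher numbers stand for lower toxicity in this test and lower numbers for higher toxicity in this test. In this assay compound 1 reaches only a limit of the assay, > 50000 nM, so no number is known for it. Its standing among the values shown is therefore fixed only by the limit of > 50000 nM in this assay, at which 1 of the 2 values shown sits. Compound 2 gives 30000 nM in this assay. Among the measured compounds shown here, no two measured compounds differ in a single place, so no measured step exists.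

Compound 3, `C=CCNC(=O)[C@@H](NC(=O)[C@@](O)(CCCN(Cc1ccc(Br)cc1)NC(=O)[C@@H](NC(=O)OC)C(C)(C)C)Cc1ccc(Br)cc1)C(C)(C)C`, has not been measured. It differs from compound 1 in one place: bromo in place of allyl on an aromatic carbon. Allyl leaves and bromo enters, on an aromatic carbon of a six-membered aromatic ring of carbon only, para to a large group; the rest of the structure is unchanged.

Since compound 1 is known only as a limit, the step is expected to be small, of no definite direction, and within the scatter: a number no higher from compound 1 to compound 3 (the limit leaves the size open). Compound 3 is accordingly estimated at 50000 nM in this assay, within a range from 20000 nM to 120000 nM. Because compound 1 sits at the limit of > 50000 nM in this assay, at which 1 of the 2 values shown sits, a limit rather than a number is the likelier outcome for compound 3 as well.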

Compound 3, half-maximal cytotoxic concentration: 29000 nM
Estimate against measurement, compound 3: 1.7-fold (0.24 log units) above; the range from low to high includes it.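

With bromo in place of allyl on an aromatic carbon, para to a large group, this assay gives an at least 1.7-fold lower number from compound 1 to compound 3 (0.23 log units; that floor lies within the scatter). Compound 3 gives a real number at this position, 29000 nM, so this single change brings the series a value that can be read, which compound 1 and compound 2 could not show for this exchange. Compound 1 itself stands only at a limit, > 50000 nM, so the true size of the step stays unknown and only its floor can be stated, and that floor does not go beyond the usual scatter: the limit of > 50000 nM in this assay, at which 1 of the 3 values shown sits.

The compounds shown leave open how other groups on this same aromatic carbon would read, such as chloro, methoxy, an amine, a carboxylic acid or a chain longer than allyl. They also leave open whether the lower number belongs to bromo in particular or would appear with any replacement of allyl, since this position is seen with only these two groups.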